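A few compounds are considered here, and "the series" means these few. Any claim that something is new, unique, unknown or untested is made for them only; others in the source may bear on it.

Measured so far in a functional assay on MIA PaCa-2 cells (Homo sapiens) for cytotoxicity, read by fluorescence, with a stated time of 48 h; on this read-out lower numbers stand for an effect already at smaller amounts and higher numbers for an effect only at larger amounts of compound:
- compound 1 (`CC(C)=CCC/C(C)=C/CC/C(C)=C/CSC[C@H](NC(=O)CCCCCN1CCCC1)C(=O)NC1CCCCC1`), with a value of 5600 nM here
- compound 2 (`CC(C)=CCC/C(C)=C/CC/C(C)=C/CSC[C@H](NC(=O)CCCCCN1CCN(C)CC1)C(=O)NC1CC1`), with a value of 10400 nM here

Compound 2 (10400 nM) and compound 1 (5600 nM) lie within the usual scatter of each other. Compound 3 (`CC(C)=CCC/C(C)=C/CC/C(C)=C/CSC[C@H](NC(=O)CCCCCN1CCN(C)CC1)C(=O)N1CCCCC1`) has piperidin-1-yl in place of cyclopropylamino on a carbonyl carbon, with the rest of compound 2 unchanged. No measured pair differs in one place, so the effect of this change has not been shown. Among the measured compounds shown here, the only guide is compound 2 (10400 nM), so no step beyond the scatter is expected. The estimated change is a 1.3-fold lower number from compound 2 to compound 3 (0.11 log units; within the scatter) and is small. In this assay the expected value for compound 3 is 8000 nM, with a range of 3000 nM to 20000 nM expected.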

Compound 3, half-maximal effective concentration: 14300 nM
For compound 3 the middle estimate is 1.8-fold (0.25 log units) below the measured one; the range from low to high includes it.
By their numbers in this assay, from the lowest: compounds 1, 2 and 3 (each within the scatter of the next, the first and the last beyond it).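

Among the compounds shown here, at this position on a carbonyl carbon, piperidin-1-yl in place of cyclopropylamino gives the first single-place comparison (a 1.4-fold higher number from compound 2 to compound 3 (0.14 log units; within the scatter)) in this assay. The hydrogen-bond donor of cyclopropylamino is lost and a larger, six-membered ring enters, yet the two numbers remain within the usual scatter of each other. No supporting measurement bears on this result.

On these data alone, it remains open whether an open-chain dimethylamino group or morpholin-4-yl at this carbonyl carbon would shift the number beyond the scatter. A carboxylic acid in place of the amide is also an open case.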